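Swapping a methoxy for a methyl on a cell-growth inhibitor

A few compounds are considered here, and "the series" means these few. Any claim that something is new, unique, unknown or untested is made for them only; others in the source may bear on it.

Four related compounds are compared in a functional assay on KYSE-450 cells (Homo sapiens) for inhibition, read by MTT assay, with a stated time of 48 h; a higher number here means a weaker inhibitor, a lower number a stronger inhibitor. Compound 1 `C/C=C/C(=O)N(Cc1ccc(OC)c(OC)c1)c1cc(OC)c(OC)c(OC)c1` gives 39100 nM in this assay, and compound 2 `C/C=C/C(=O)N(Cc1ccc(OC)c(C)c1)c1cc(OC)c(OC)c(OC)c1` gives 32900 nM. The two differ in one place, (methyl in place of methoxy on an aromatic carbon), and the step is a 1.2-fold lower number from compound 1 to compound 2 (0.07 log units; within the scatter). Compound 3 `COc1ccc(CNc2cc(OC)c(OC)c(OC)c2)cc1` gives 4890 nM in this assay, the lowest of the three measured numbers; its nearest neighbour, compound 2, sits a good deal higher, and compound 1 higher still, both beyond the usual scatter. How the core of compound 3 differs from the core of compound 1 is not broken down here; they differ in more than one place.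

Compound 4 `COc1cc(NCc2ccc(C)cc2)cc(OC)c1OC` has not been measured. It differs from compound 3 by methyl in place of methoxy on an aromatic carbon. This is the same kind of change as that from compound 1 to compound 2, but not the same change: in compound 4 the methyl stands para to a large group, whereas in compound 2 it stands ortho to a methoxy group and meta to a large group.

Because the step of a 1.2-fold lower number from compound 1 to compound 2 (0.07 log units; within the scatter) stayed within the scatter, the corresponding step from compound 3 to compound 4 is expected to be small as well, about a 1.1-fold lower number from compound 3 to compound 4 (0.04 log units; within the scatter). On that basis compound 4 is estimated to give 4500 nM in this assay, most likely between 1500 nM and 13000 nM.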

Compound 4, half-maximal inhibitory concentration: > 80000 nM
Compound 4 gave a limit, no number; the forecaster's own chance of this, stated with the estimate: 5%; middle value at least 17-fold (1.24 log units) away from the limit.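

In this assay compound 4 gives > 80000 nM, which is a limit of the assay and not a number. The step is an at least 16-fold higher number from compound 3 to compound 4 (1.21 log units; beyond the scatter), so methyl in place of methoxy cannot be carried from one core to the other as a fixed shift, and a small step on one core gives no safe forecast for the other: the same change on two cores in this assay, a 1.2-fold lower number (0.07 log units; within the scatter) from compound 1 to compound 2 and an at least 16-fold higher number (1.21 log units; beyond the scatter) from compound 3 to compound 4, at least 19-fold (1.28 log units) apart, beyond the scatter of two such steps. What this does not show is why the two pairs part ways, as the cores differ in more than one place, the methyl of compound 4 stands para to a large group, and two pairs cannot separate the effect of the core from that of the place of the change.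

The compounds shown leave open whether the drop in potency comes from losing the methoxy or from gaining the methyl, a question that a chlorine, an ethyl or a hydroxyl in the same place on the core of compound 3 could help to answer. Also open, from the compounds shown here alone, is how far beyond the limit the true value of compound 4 lies, and with it the full size of the step.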